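The source may report more compounds than this note shows. Statements on the series, on what has been measured and on what is new or still open speak of the compounds shown alone.

Measured so far in a functional assay on HOS-TE85 cells (Homo sapiens) for inhibition, read by CCK-8 assay, with a stated time of 72 h; on this read-out lower numbers stand for stronger inhibition and higher numbers for weaker inhibition:
compound 1 `CC1SC(c2cccc(C(=O)NCCCCc3ccccc3)c2)N(c2ccc(C3CC3)cc2)C1=O`: 191 nM
compound 2 `O=C(NCCCCc1ccccc1)c1cccc(C2SCC(=O)N2c2cccc(-c3c[nH]nn3)c2)c1`: 110 nM
compound 3 `Cc1ccnc(N2C(=O)CS[C@H]2c2cccc(C(=O)NCCCCn3cccn3)c2)c1`: > 10000 nM

Compound 2 has the lower of the two numbers in this assay, but the gap to compound 1 is within the usual scatter, so the two cannot be told apart. Compound 3 gives only a limit in this assay, (the limit of > 10000 nM in this assay, at which 1 of the 3 values shown sits); it differs from compound 2 in more than one place, so nothing can be tied to any single change.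

Compound 4 `COc1ccc(N2C(=O)CSC2c2cccc(C(=O)NCCCCc3ccccc3)c2)c(OC)c1` is not yet measured in this assay. It differs from compound 2 in one place: a group of 10 heavy atoms (8 carbon, 2 oxygen; one six-membered aromatic ring of carbon only) in place of a group of 11 heavy atoms (8 carbon, 3 nitrogen; one five-membered aromatic ring with 3 hetero atoms, one six-membered aromatic ring of carbon only), on an amide-type nitrogen in a ring

Among the measured compounds shown here, no measured pair differs in one place, so no step gives a yardstick for this change. Compound 1 and compound 2 carry different groups on the same ring nitrogen and sit within the scatter of each other, which suggests this position tolerates variation; the 2,4-dimethoxyphenyl is a further untested variant. The expected step from compound 2 to compound 4 is a 2.7-fold higher number from compound 2 to compound 4 (0.44 log units; beyond the scatter), a modest weakening, with the outcome uncertain enough to span the scatter. Compound 4 is thus estimated at 300 nM in this assay, between 80 nM and 1500 nM.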

Compound 4, half-maximal inhibitory concentration: 90.4 nM
Beside the measured number, compound 4's estimate is 3.3-fold (0.52 log units) above it; the range from low to high includes it.
By their numbers in this assay, from the lowest: compounds 4, 2 and 1 (each within the scatter of the next, the first and the last beyond it). At a limit, above all of these: compound 3.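

Working notes on the amide-type nitrogen of the ring: this is the first single-place step at this position. Replacing the group containing the five-membered aromatic ring with 3 hetero atoms by 2,4-dimethoxyphenyl gives, in this assay, a 1.2-fold lower number from compound 2 to compound 4 (0.09 log units; within the scatter), within the scatter, so the two compounds cannot be told apart. In this pair, neither that five-membered aromatic ring nor a hydrogen-bond donor in the group is needed to keep a number in this range, although the pair alone cannot show how far this extends to other groups. No measured property available here bears on this result.

Going by these compounds, whether both methoxy groups contribute remains open, since an unsubstituted phenyl or a single methoxy group would be needed to separate them. Also open, on these data alone, is how a carboxylic acid or an amine on this phenyl ring would read in this assay.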